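Adding propyl to the piperazine ring of compound 2

This account rests on a few compounds, and the source may have more. Where it says the series, first, only, none or still open, it means among the compounds named here.

Compound 1 `O=C1c2c[n+]([O-])c3ccccc3c2C(=O)c2c1c1ccccc1n2Cc1cn(C[C@H](O)CO)nn1`: 1310 nM
Compound 2 `O=C1c2c[n+]([O-])c3ccccc3c2C(=O)c2c1c1ccccc1n2CCCCN1CCNCC1`: 3310 nM

In a functional assay on MDA-MB-231 cells (Homo sapiens) for cytotoxicity, read by MTT assay, with a stated time of 72 h (on this read-out lower numbers stand for stronger inhibition and higher numbers for weaker inhibition), compound 2 holds the higher of the two numbers. Within the data shown here, the only measured step is a 2.5-fold higher number from compound 1 to compound 2 (0.40 log units; beyond the scatter) and it exchanges the whole side group on the chain carbon bound to the aromatic nitrogen. Compound 3 `CCCN1CCN(CCCCn2c3c(c4ccccc42)C(=O)c2c[n+]([O-])c4ccccc4c2C3=O)CC1` keeps the rest of compound 2 and carries one change: propyl in place of hydrogen on an amine nitrogen in a ring. Among the measured compounds shown here, the measured step bears on this only loosely, and no measured compound carries a substituent on that nitrogen. The data therefore give no firm direction. Taking compound 2 at 3310 nM as the starting point and the modest 2.5-fold higher number from compound 1 to compound 2 (0.40 log units; beyond the scatter) as a rough guide to size, a small change is expected in this assay at most. The expected step is a 1.1-fold lower number from compound 2 to compound 3 (0.04 log units; within the scatter) and it carries little confidence in its direction. Compound 3 is estimated at 3000 nM in this assay with 1200 nM to 7500 nM as the expected range.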

Compound 3, half-maximal inhibitory concentration: 2980 nM
Beside the measured number, compound 3's estimate is 1.0-fold (0.00 log units) above it; measured number inside the range.
By their numbers in this assay, from the lowest: compound 1; then compounds 3 and 2 (each within the scatter of the next).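

In this assay, the exchange of piperazin-1-yl for 4-propylpiperazin-1-yl gives a 1.1-fold lower number from compound 2 to compound 3 (0.05 log units; within the scatter), so the two numbers cannot be told apart and, at this amine nitrogen in the ring, propyl reads the same as hydrogen in this cell assay. Among these compounds, this is the first reading at that nitrogen, and it shows that the position accepts this alkyl group without a difference beyond the scatter. The wider exchange of side groups gives a 2.3-fold higher number from compound 1 to compound 3 (0.36 log units; beyond the scatter), so compound 1 keeps the lowest number of the three, with both piperazine compounds on the higher side of it, and no evidence at hand speaks to what lies behind these readings.

On these data alone, whether the same holds for a longer chain such as hexyl, a benzyl group, an acetyl group or a carboxylic acid on that nitrogen remains open, as a single alkyl group says little about the range the position tolerates. Also open, as far as these compounds go, is which part of the side group of compound 1 goes with its lower number, a question that a triazole lacking the dihydroxypropyl group could address.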